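From Nitro to Chloro at an Assay Limit

A few compounds are considered here, and "the series" means these few. Any claim that something is new, unique, unknown or untested is made for them only; others in the source may bear on it.

Two measured compounds share one core: compound 1 (`O=[N+]([O-])c1ccccc1Nc1nnc(-c2c[nH]c3ccccc23)o1`) and compound 2 (`O=[N+]([O-])c1cccc(Nc2nnc(-c3c[nH]c4ccccc34)o2)c1`). In a functional assay on Jurkat cells (Homo sapiens) for inhibition, with a stated time of 24 h (a lower number here means a stronger inhibitor, a higher number a weaker inhibitor), compound 1 gives 30200 nM as a measured number. Compound 2 gives > 100000 nM in this assay and this is a limit, not a number.

Compound 3 (`Clc1cccc(Nc2nnc(-c3c[nH]c4ccccc34)o2)c1`) has not yet been measured. It differs from compound 2 in one place, with chloro in place of nitro on an aromatic carbon. The change sits meta to a large group.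

Two compounds make a thin basis for a forecast, and neither carries chloro, so any expectation stays loose. A measured number is within reach for this core, as compound 1 shows with 30200 nM in this assay so a modest gain in inhibition is expected. The estimated change is an at least 2.0-fold lower number from compound 2 to compound 3 (0.30 log units; that floor lies within the scatter) in this assay and it points toward stronger inhibition. For compound 3 the estimated half-maximal inhibitory concentration is 50000 nM with an expected range of 18000 nM to 100000 nM in this assay. Compound 3 may also turn out to give only a limit.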

Compound 3, half-maximal inhibitory concentration: > 100000 nM
Compound 3 gave a limit, no number; the forecaster's own chance of this, stated with the estimate: 35%; at least 2.0-fold (0.30 log units) between middle value and limit.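

Compound 2 and compound 3 each give only a limit, not a number, so no step between them can be read, because both rest on the same ceiling: the limit of > 100000 nM in this assay, at which 2 of the 3 values shown sit.

The compounds shown leave open whether chloro in place of nitro on an aromatic carbon changes inhibition at all in this assay, and by how much.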